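This account rests on a few compounds, and the source may have more. Where it says the series, first, only, none or still open, it means among the compounds named here.

The series rests on compound 1 `O=C(/C(=C\c1ccc(Cl)cc1Cl)S(=O)(=O)c1ccc(Br)cc1)c1ccc(Br)cc1`, which in a functional assay on DU-145 cells (Homo sapiens) for inhibition, read by trypan blue exclusion, with a stated time of 96 h (on this read-out higher numbers stand for weaker inhibition of growth and lower numbers for stronger inhibition of growth), gives 10000 nM. Compound 3 `Cc1cc(C)cc(/C=C(/SCc2ccc(Cl)cc2)C(=O)c2ccc(Cl)cc2)c1` gives 10000 nM in this assay, the same number at the digits shown, so the two sit together within the scatter. Going by the values given here, compound 2 `COc1ccc(S(=O)(=O)/C(=C/c2ccc(Cl)cc2Cl)C(=O)c2ccc(Br)cc2)cc1` gives 20000 nM in this assay; the only single-point step among the measured compounds, a 2.0-fold higher number from compound 1 to compound 2 (0.30 log units; within the scatter), stays within the scatter.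

Compound 4 `O=C(/C(=C\c1ccc(F)c([N+](=O)[O-])c1)S(=O)(=O)c1ccc(Br)cc1)c1ccc(Br)cc1` has not been measured. It differs from compound 1 by 4-fluoro-3-nitrophenyl in place of 2,4-dichlorophenyl on a double-bonded chain carbon bound to a double-bonded chain carbon. Among the compounds with values here, no measured step touches this place: the one known step, a methoxy for a bromo on an aromatic carbon, concerns a different part of the shared core and was itself within the scatter, so nothing in the data points in either direction. The expectation for compound 4 is therefore a step in this assay of no change at the digits printed from compound 1 to compound 4 (within the scatter), that is, no change beyond the scatter. Compound 4 is thus estimated at 10000 nM in this assay, with a range from 3000 nM to 30000 nM.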

Compound 4, concentration for 50% growth inhibition: 25000 nM
The estimate for compound 4 lay 2.5-fold (0.40 log units) below the measured number, within the range that was stated.
By their numbers in this assay, from the lowest: compounds 1, 3, 2 and 4 (each within the scatter of the next, the first and the last beyond it).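

Going by these compounds alone, this is the first change at the aryl group on a double-bonded chain carbon bound to a double-bonded chain carbon, and in this assay replacing 2,4-dichlorophenyl with 4-fluoro-3-nitrophenyl gives a 2.5-fold higher number from compound 1 to compound 4 (0.40 log units; beyond the scatter), a modest move toward weaker inhibition of growth. Within the data shown here, the earlier single-point step lay elsewhere on the shared core and stayed within the scatter, so this position is the first to show a change beyond it. No measurement at hand bears on why this step occurs.

A single replacement cannot separate the loss of the two chlorines from the entry of the fluoro and nitro groups. Going by these compounds, it also remains open how an unsubstituted phenyl, a 4-aminophenyl or a 4-carboxyphenyl would behave at this place.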